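The source may hold more compounds than are shown below. What is called first, only, known or untested is meant among the compounds shown, and "the series" means these compounds.

Values in a physicochemical assay for solubility, using the shake flask method, in phosphate buffer, with a stated time of 20 h, at pH 6.5; on this read-out lower numbers stand for lower solubility and higher numbers for higher solubility:
- Compound 1 `C[S+]([O-])c1ccc(-c2ccc3ncc(-c4ccc([S+](C)[O-])cc4)n3n2)cc1`: 200000 nM
- Compound 2 `C[S+]([O-])c1ccc(-c2cnc3ccc(NC4CCS(=O)(=O)CC4)nn23)cc1`: 10000 nM
- Compound 3 `CCN(CC)Cc1cc(Nc2ccc3ncc(-c4ccc([S+](C)[O-])cc4)n3n2)ccc1F`: 200000 nM

Compound 3 sits level with compound 1 at the digits shown, at 200000 nM. Both stand well clear of compound 2, which gives 10000 nM.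

Compound 4 `CCN(CC)Cc1cc(Nc2ccc3ncc(-c4ccc([S+](C)[O-])cc4)n3n2)ccc1O` differs from compound 3 in a single place: hydroxy in place of fluoro on an aromatic carbon. Put simply, this is hydroxy in place of fluoro on an aromatic carbon.

Among the measured compounds shown here, only one measured step exists to compare it with, a 20-fold lower number from compound 1 to compound 2 (1.30 log units; beyond the scatter). That step is large, but it replaces a whole ring-bearing group rather than a fluoro. For the measured compounds named here, no measured pair shows the fluoro-to-hydroxy exchange, so this step says little about the size to expect here. With nothing pointing firmly either way in this assay, the expected outcome is a small one, a 1.1-fold lower number from compound 3 to compound 4 (0.05 log units; within the scatter), which would not stand out from the scatter. For compound 4 the estimated value is 180000 nM, with an expected range from 70000 nM to 250000 nM.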

Compound 4, solubility: 195000 nM
Beside the measured number, compound 4's estimate is 1.1-fold (0.03 log units) below it; the measured number falls inside the stated range.
By their numbers in this assay, from the lowest: compound 2; then compounds 4, 1 and 3 (each within the scatter of the next).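

In this assay, hydroxy in place of fluoro on this aromatic carbon, ortho to a (diethylamino)methyl group and para to a large group, gives a 1.0-fold lower number from compound 3 to compound 4 (0.01 log units; within the scatter), so the two compounds cannot be told apart. Among the compounds shown here, this is the first view of this position, and it shows that a hydroxy, which carries a hydrogen-bond donor and acceptor that fluoro lacks, can stand here with no change beyond the scatter. Nothing available explains this result.

On these data alone, whether a methoxy group, an amine or a carboxylic acid on this same carbon would also stay within the scatter of compound 3 remains open. A single pair also cannot show whether this exchange would read the same way elsewhere in the series.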